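Swapping a bulky group for iodine on the amide

This account rests on a few compounds, and the source may have more. Where it says the series, first, only, none or still open, it means among the compounds named here.

Of the compounds shown here, three built on one shared core have been tested in a functional assay on MCF7 cells (Homo sapiens) for inhibition, read by MTT assay; on this read-out lower numbers stand for stronger inhibition and higher numbers for weaker inhibition. Compound 1 `COc1cc2ncnc(Nc3ccc(NC(=O)c4cccc(C)c4)cc3)c2cc1OC` gives 13000 nM. Compound 3 `COc1cc2ncnc(Nc3ccc(NC(=O)c4ccccc4I)cc3)c2cc1OC` gives 37000 nM. Compound 2 `COc1cc2ncnc(Nc3ccc(NC(=O)c4ccc(C(C)(C)C)cc4)cc3)c2cc1OC` reaches only a limit of the assay, > 100000 nM, so for it no number is known; it stands at the weak end of the three, as the limit of > 100000 nM in this assay, at which 1 of the 3 values shown sits, shows.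

Compound 4 `COc1cc2ncnc(Nc3ccc(NC(=O)c4cccc(I)c4)cc3)c2cc1OC` has not yet been measured. It differs from compound 2 by 3-iodophenyl in place of 4-(tert-butyl)phenyl on a carbonyl carbon. Among the compounds with values here, three measured steps bear on this change. an at least 2.7-fold lower number from compound 2 to compound 3 (0.43 log units; beyond the scatter) shows that replacing the 4-(tert-butyl)phenyl with an iodophenyl gave a lower number. an at least 7.6-fold higher number from compound 1 to compound 2 (0.88 log units; beyond the scatter) shows that the 4-(tert-butyl)phenyl reads higher than the 3-methylphenyl of compound 1. a 2.8-fold higher number from compound 1 to compound 3 (0.45 log units; beyond the scatter) shows that moving from 3-methylphenyl to 2-iodophenyl gave a modestly higher number. A step to a clearly lower number is therefore expected, of the size an at least 5.0-fold lower number from compound 2 to compound 4 (0.69 log units; beyond the scatter). In this assay compound 4 is estimated at 20000 nM, with a range from 6000 nM to 70000 nM.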

Compound 4, half-maximal inhibitory concentration: 30000 nM
The estimate for compound 4 lay 1.5-fold (0.18 log units) below the measured number, and the stated range covers the measured number.
By their numbers in this assay, from the lowest: compound 1; then compounds 4 and 3 (each within the scatter of the next). At a limit, above all of these: compound 2.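

Moving the iodine makes no real difference here: a 1.2-fold lower number from compound 3 to compound 4 (0.09 log units; within the scatter), so 2-iodophenyl and 3-iodophenyl cannot be told apart on this read-out. Iodo in place of methyl on an aromatic carbon gives a modest step, a 2.3-fold higher number from compound 1 to compound 4 (0.36 log units; beyond the scatter), so this single-atom exchange on the ring is enough to separate the two compounds beyond the scatter. The step away from 4-(tert-butyl)phenyl, an at least 3.3-fold lower number from compound 2 to compound 4 (0.52 log units; beyond the scatter), gives only a minimum size, since compound 2 has no true number, only a limit: the limit of > 100000 nM in this assay, at which 1 of the 4 values shown sits.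

The compounds shown leave open whether an amine or a carboxylic acid in place of the iodo would bring the number closer to that of the 3-methylphenyl or push it higher. They also do not tell what lies behind these differences.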